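This account rests on a few compounds, and the source may have more. Where it says the series, first, only, none or still open, it means among the compounds named here.

Notes on the series. Compound 1 `Cc1cccc(-c2noc(C3CN(C(=O)c4ccccc4F)C3)n2)c1` and compound 2 `O=C(c1ccccc1F)N1CC(c2nc(-c3cccc(Cl)c3)no2)C1` share a core and differ only at one aromatic carbon. Among the measured compounds shown here, in an assay on HEK293 cells for negative allosteric modulation of metabotropic glutamate receptor 5 (Homo sapiens), read by FLIPR (a lower number here means a stronger inhibitor, a higher number a weaker inhibitor), compound 1 gives 1400 nM; compound 2 gives 670 nM, which is the lowest of the two numbers so far. For the measured compounds named here, the only measured step, a 2.1-fold lower number from compound 1 to compound 2 (0.32 log units; beyond the scatter), concerns the substituent on the pendant aromatic ring and nothing else.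

Compound 3 `O=C(C1CCCO1)N1CC(c2nc(-c3cccc(Cl)c3)no2)C1` is not yet measured. Its change from compound 2 is oxolan-2-yl in place of 2-fluorophenyl on a carbonyl carbon. Going by the values given here, the measured step from compound 1 to compound 2 touches a different part of the molecule and therefore says nothing direct about this exchange; no measured pair varies the group on the carbonyl carbon. The expectation for compound 3 thus rests on compound 2 alone, with wide uncertainty, and the step of a 3.7-fold higher number from compound 2 to compound 3 (0.57 log units; beyond the scatter) is expected to run toward a higher number rather than a lower one. For compound 3 the estimate in this assay is 2500 nM, with a range from 600 nM to 10000 nM.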

Compound 3, half-maximal inhibitory concentration: 890 nM
Compound 3: the middle estimate sits 2.8-fold (0.45 log units) above what was measured; the measured number falls inside the stated range.
By their numbers in this assay, from the lowest: compounds 2, 3 and 1 (each within the scatter of the next, the first and the last beyond it).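

Among the compounds shown here, the exchange on the carbonyl carbon, with its amide-type nitrogen in a ring as the other neighbour, can now be read for the first time: in this assay it gives a 1.3-fold higher number from compound 2 to compound 3 (0.12 log units; within the scatter) and so does not separate oxolan-2-yl from 2-fluorophenyl at this place. Within this one pair, a five-membered non-aromatic ring with 1 hetero atom and 1 hydrogen-bond acceptor stands where a six-membered aromatic ring of carbon only stood, with no reading beyond the scatter, so an aromatic ring on this carbonyl carbon is not needed for a number in this range when the chloro group is present. No supporting data bear on why the two groups read alike.

Oxolan-2-yl appears here only together with the chloro group, so whether the same holds with methyl on that aromatic carbon stays open. Also open, as far as these compounds go, is how the number in this assay responds when an amine, a carboxylic acid or a longer open carbon chain stands on the carbonyl carbon, since two ring groups alone give no trend at this place.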